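Swapping a Morpholine for a Piperidine on Chromone Dithiocarbamates

This account rests on a few compounds, and the source may have more. Where it says the series, first, only, none or still open, it means among the compounds named here.

Of the compounds shown here, three have been tested in a functional assay on LM7 cells (Homo sapiens) for antiproliferative activity, read by MTT assay, with a stated time of 72 h; a lower number here means a stronger inhibitor, a higher number a weaker inhibitor. Compound 1 `COc1ccc2oc(CSC(=S)N3CCOCC3)cc(=O)c2c1` gives 11000 nM in this assay. Compound 2 `O=c1c(CSC(=S)N2CCOCC2)coc2cc(Cl)ccc12` gives 6200 nM. Compound 3 `COc1ccc2oc(CSC(=S)N3CCCCC3)cc(=O)c2c1` gives 5000 nM. The values of compound 2 and compound 3 lie within the usual scatter of each other, and so do those of compound 2 and compound 1, so no order among them can be read from these numbers. The difference between the core of compound 1 and the core of compound 2 is not broken down here.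

Compound 3 is derived from compound 1 by one change, (piperidin-1-yl in place of morpholin-4-yl on a thiocarbonyl carbon), and this change gave a 2.2-fold lower number from compound 1 to compound 3 (0.34 log units; beyond the scatter).

Compound 4 `O=c1c(CSC(=S)N2CCCCC2)coc2cc(Cl)ccc12` has not yet been tested. It stands to compound 2 as compound 3 stands to compound 1: piperidin-1-yl in place of morpholin-4-yl on a thiocarbonyl carbon. The same kind of change in the same place is therefore seen twice among these compounds. Because the first step was a 2.2-fold lower number from compound 1 to compound 3 (0.34 log units; beyond the scatter), a step of similar size, a 2.2-fold lower number from compound 2 to compound 4 (0.35 log units; beyond the scatter), is expected in this assay. Compound 4 is therefore estimated at 2800 nM, within a range from 1400 nM to 5600 nM.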

Compound 4, half-maximal inhibitory concentration: 850 nM
For compound 4 the middle estimate is 3.3-fold (0.52 log units) above the measured one, and the stated range ends above it.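

In this assay, placing piperidin-1-yl in place of morpholin-4-yl on a thiocarbonyl carbon gives a 7.3-fold lower number from compound 2 to compound 4 (0.86 log units; beyond the scatter). The direction of the first step therefore holds on the second core, but its size does not carry over, and the two steps differ by more than ordinary measurement noise would allow: the same change on two cores in this assay, a 2.2-fold lower number (0.34 log units; beyond the scatter) from compound 1 to compound 3 and a 7.3-fold lower number (0.86 log units; beyond the scatter) from compound 2 to compound 4, 3.3-fold (0.52 log units) apart, beyond the scatter of two such steps. This shows that, among these four compounds, a step measured on one core gave the right direction on the other but not a reliable size, while two cores are too few to support a rule for the wider series or to say why the sizes differ.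

The compounds shown leave open which part of the difference between the two cores matters for the size of the step. They also leave open how the thiocarbonyl carbon would tolerate other amines, such as pyrrolidine, a piperazine or an open-chain diethylamine, and whether those groups would show the same dependence on the core.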